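Swapping the Aryl Group on a Sulfonamide Nitrogen

This account rests on a few compounds, and the source may have more. Where it says the series, first, only, none or still open, it means among the compounds named here.

Measured so far in a physicochemical assay for lipophilicity, at pH 7.4; a higher number here means a more lipophilic compound, a lower number a more polar compound:
compound 1 `CCc1ccc(NS(=O)(=O)c2ccc3c(c2)C(O)CC(C2CCOCC2)O3)cc1` gives 2.59
compound 2 `CC(C)CN(c1ccc(C#N)cc1)S(=O)(=O)c1ccc2c(c1)C(O)CC(C1CCOCC1)O2` gives 3.07
compound 3 `CCc1ccc(N(CC(C)C)S(=O)(=O)c2ccc3c(c2)C(N)CC(C2CCOCC2)O3)cc1` gives 3.08

Among these three, compound 2 sits second highest. Its value and that of compound 3 lie within the scatter of each other, so no order can be read between them; compound 1 lies clearly lower, beyond the scatter. The next compound, compound 4 `CC(C)CN(c1ccccc1C(F)(F)F)S(=O)(=O)c1ccc2c(c1)C(O)CC(C1CCOCC1)O2`, is not yet measured in this assay. It departs from compound 2 in one place: 2-(trifluoromethyl)phenyl in place of 4-cyanophenyl on a sulfonamide nitrogen. Since a hydrogen-bond acceptor leaves and none enters, a rise beyond the scatter is expected in this assay. Compound 4 is estimated at 3.9, between 3.4 and 4.4, a step of a number 0.83 log units higher from compound 2 to compound 4 (beyond the scatter) expected.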

Compound 4, distribution coefficient: 4.14
The estimate for compound 4 lay 0.24 log units below the measured number; the measured number falls inside the stated range.
By their numbers in this assay, from the lowest: compound 1; then compounds 2 and 3 (each within the scatter of the next); then compound 4.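

The swap of 4-cyanophenyl for 2-(trifluoromethyl)phenyl on a sulfonamide nitrogen gives, in this assay, a step of a number 1.07 log units higher from compound 2 to compound 4 (beyond the scatter) and so shows that the aryl group at this position can carry a large change. Among these compounds, the earlier compounds offered no step in one place, so this is the first direct reading here. No measurement shown bears on what lies behind the step. Still open, as far as these compounds go, is how much belongs to losing the nitrile and how much to gaining the trifluoromethyl. From the compounds shown here alone, how an unsubstituted phenyl, a pyridine ring or an aryl ring bearing a carboxylic acid would read at this position also remains open.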